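The compounds below may be only part of what the source reports. "The series", "measured", "known", "first", "only" and "open" are said of these compounds alone.

Compound 2, with structure `Cc1ccc(S(=O)(=O)Cc2ccccc2)cc1C#Cc1cc(Cl)ccc1OCC(=O)O`, is the stronger of the two measured compounds in an assay on CHO cells for displacement of a labelled ligand from prostaglandin D2 receptor 2 (Homo sapiens), read by scintillation counting (a higher number here means a weaker inhibitor, a lower number a stronger inhibitor), where compound 2 gives 5 nM. Among the compounds with values here, its only neighbour, compound 1, with structure `O=C(O)COc1ccc(Cl)cc1C#Cc1cccc(CO)c1F`, gives 41 nM in this assay, a higher number that lies beyond the scatter, so compound 2 holds the lower value of the pair with room to spare. Compounds 1 and 2 differ in more than one place, so their gap is not tied to any single change.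

The step under consideration leads to compound 3, with structure `Cc1ccc(S(C)(=O)=O)cc1C#Cc1cc(Cl)ccc1OCC(=O)O`, which has not yet been measured in this assay. The change is hydrogen in place of phenyl on a saturated chain carbon bound to a sulfonyl sulfur — that is, the benzylsulfonyl of compound 2 becomes a methylsulfonyl in compound 3. Within the data shown here, nothing among the measured compounds shows what this change alone does in this assay.

Compound 3 is therefore expected to give a somewhat higher number than compound 2, a modest loss, so the estimated step is a 3.0-fold higher number from compound 2 to compound 3 (0.48 log units; beyond the scatter). Compound 3 is estimated at 15 nM, with a range from 5 nM to 50 nM.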

Compound 3, inhibition constant: 5 nM
Beside the measured number, compound 3's estimate is 3.0-fold (0.48 log units) above it, within the range that was stated.
By their numbers in this assay, from the lowest: compounds 2 and 3 (each within the scatter of the next); then compound 1.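

In this assay, hydrogen in place of phenyl on the saturated chain carbon bound to the sulfonyl sulfur gives no change at the digits printed from compound 2 to compound 3 (within the scatter) and so leaves the benzylsulfonyl and methylsulfonyl compounds level. Within the data shown here, this is the first comparison that isolates a single place, and it shows that, in this pair, a number of this size does not require the phenyl, a group of six carbon atoms forming one aromatic ring. No measurement at hand offers an explanation for the two compounds standing level.

The compounds shown leave open whether other groups on this saturated chain carbon, such as a longer chain, an amine or a carboxylic acid, would give a value level with those of compound 2 and compound 3, or a clearly different one. Compound 1 differs from compound 2 and from compound 3 in more than one place, and its gap to them cannot yet be tied to any single change.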